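Working notes: carbamate to cyclic replacement, compound 3 pending

The compounds below may be only part of what the source reports. "The series", "measured", "known", "first", "only" and "open" are said of these compounds alone.

Measured so far:
compound 1 `COC(=O)N(Cc1ccccc1F)c1c(N)nc(-c2nn(Cc3ccccc3F)c3ncccc23)nc1N` — 0.1 uM
compound 2 `Nc1nc(-c2nn(Cc3ccccc3F)c3ncccc23)nc(N)c1NC(=O)OC1COC1` — 2.3 uM

Two compounds have been run in an assay on cells for activation of Guanylate cyclase soluble subunit alpha-1 (Rattus norvegicus), read by cGMP accumulation and immunoassay, with a stated time of 10 min; on this read-out higher numbers stand for an effect only at larger amounts of compound and lower numbers for an effect already at smaller amounts. Compound 1 gives 0.1 uM, and compound 2 gives 2.3 uM. Compound 2 therefore holds the higher of the two numbers; its gap to compound 1 lies beyond the usual scatter, and compound 1 is the only comparator available. Among the compounds with values here, no pair of these two differs in a single place, so no isolated step can be read from them.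

Compound 3 `Nc1nc(-c2nn(Cc3ccccc3F)c3ncccc23)nc(N)c1N1C[C@H](C(F)(F)F)OC1=O` is the next candidate. Relative to compound 2 it carries the change (a group of 10 heavy atoms (4 carbon, 1 nitrogen, 2 oxygen, 3 fluorine; one five-membered non-aromatic ring with 2 hetero atoms) in place of a group of 8 heavy atoms (4 carbon, 1 nitrogen, 3 oxygen; one four-membered non-aromatic ring with 1 hetero atom), on an aromatic carbon). Nothing measured tracks this exact exchange, so the direction of the step is open. On balance the step from compound 2 to compound 3 in this assay is expected to be modest and downward, a 2.3-fold lower number from compound 2 to compound 3 (0.36 log units; beyond the scatter), with a real chance that it stays within the scatter. Compound 3 is estimated at 1 uM in this assay, in a range from 0.2 uM to 5 uM.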

Compound 3, minimum effective concentration: 0.2 uM
For compound 3 the middle estimate is 5.0-fold (0.70 log units) above the measured one; low and high end bracket the measured number.
By their numbers in this assay, from the lowest: compounds 1 and 3 (each within the scatter of the next); then compound 2.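

Working notes, position on the aromatic carbon ortho to two amino groups: in this assay this position responds strongly to the group it carries, since replacing (((oxetan-3-yl)oxy)carbonyl)amino with the five-membered non-aromatic ring with 2 hetero atoms gives a 12-fold lower number from compound 2 to compound 3 (1.06 log units; beyond the scatter). The entering group has 0 hydrogen-bond donors against 1 in the group it replaces, so within this pair a donor on this group is not needed for the number of compound 3, 0.2 uM. The exchange alters ring size, hetero atoms, fluorine content and stereochemistry at once, and no measurement on hand separates these changes or explains the step.

On these data alone, it remains open which part of the exchange carries the step, for example whether a methyl group or a plain hydrogen in place of the trifluoromethyl on the ring, or the opposite configuration at the stereocentre, would keep the number close to that of compound 3. Also open, as far as these compounds go, is how a simple amine at this position would compare with the two groups in this pair.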